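This account rests on a few compounds, and the source may have more. Where it says the series, first, only, none or still open, it means among the compounds named here.

The read-out throughout is a physicochemical assay for solubility, at pH 6.8; on this read-out lower numbers stand for lower solubility and higher numbers for higher solubility. Compound 1 `Cc1c(COc2cccc(OCC3CCOCC3)c2)[nH]c2ccc(-c3cccnc3)cc2c1=O` is the starting point. In this assay compound 1 gives < 1000 nM, which is a limit of the assay and not a measured number. Two other compounds share parts of its structure. Compound 2 `O=c1cc(COc2cccc(OCC3CCOCC3)c2)[nH]c2ccccc12` gives 4000 nM in this assay. Compound 3 `Cc1c(COc2cncc(OCCC(C)(C)O)c2)[nH]c2ccccc2c1=O` gives >= 100000 nM in this assay, again a limit of the assay. So compound 1 stands at one end of what is known: the limit of < 1000 nM in this assay, at which 1 of the 3 values shown sits, while the limit of >= 100000 nM in this assay, at which 1 of the 3 values shown sits, marks the opposite end, and only compound 2 carries an actual number.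

Compound 4 `Cc1c(COc2cccc(OCC3CCOCC3)c2)[nH]c2ccc(Br)cc2c1=O` is not yet measured. It differs from compound 1 in one place bromo in place of pyridin-3-yl on an aromatic carbon of a six-membered aromatic ring of carbon only, part of a fused system of two rings. Going by the values given here, no measured pair of compounds repeats this change, so the expectation rests on the position of compound 1 alone. Since compound 1 sits at a limit, the expected step from compound 1 to compound 4 is a step that the limit leaves unreadable from compound 1 to compound 4, within the scatter. Compound 4 is therefore estimated at 600 nM, between 150 nM and 2500 nM, most likely reported again as a limit.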

Compound 4, solubility: < 1000 nM
Compound 4: a limit, no number; the forecaster's own chance of this, stated with the estimate: 65%; the middle value is on the limit's open side.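

In this assay compound 4 gives < 1000 nM, a limit of the assay and not a number. Going by these compounds alone, compound 1 sits at the same limit, so no step between them can be read. The compounds shown leave open how far past that limit each one lies, and whether bromo and pyridin-3-yl differ at all.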